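A few compounds are considered here, and "the series" means these few. Any claim that something is new, unique, unknown or untested is made for them only; others in the source may bear on it.

Measured so far: compound 1 `COc1ccc(NC(=O)/C=C/C(=O)N2C/C(=C\c3ccccc3)C(=O)/C(=C/c3ccccc3)C2)cc1`, compound 2 `Cc1ccc(NC(=O)/C=C/C(=O)N2C/C(=C\c3ccccc3)C(=O)/C(=C/c3ccccc3)C2)cc1C`, compound 3 `O=C(/C=C/C(=O)N1C/C(=C\c2ccccc2)C(=O)/C(=C/c2ccccc2)C1)Nc1ccc([N+](=O)[O-])cc1`.

In a functional assay on L1210 cells (Mus musculus) for cytotoxicity (a lower number here means a stronger inhibitor, a higher number a weaker inhibitor), compound 1 gives 6800 nM, compound 2 gives 31000 nM, and compound 3 gives 40000 nM. Compound 3 carries the highest number of the three, since a 5.9-fold higher number from compound 1 to compound 3 (0.77 log units; beyond the scatter), although a 1.3-fold higher number from compound 2 to compound 3 (0.11 log units; within the scatter). Compound 4 `Cc1cccc(C)c1NC(=O)/C=C/C(=O)N1C/C(=C\c2ccccc2)C(=O)/C(=C/c2ccccc2)C1` differs from compound 3 in one place: 2,6-dimethylphenyl in place of 4-nitrophenyl on an amide-type nitrogen. For the measured compounds named here, the step that bears on this is the one in which compound 2, bearing 3,4-dimethylphenyl, gives way to compound 3, where a 1.3-fold higher number from compound 2 to compound 3 (0.11 log units; within the scatter). Compound 2 in turn sits where a 4.6-fold higher number from compound 1 to compound 2 (0.66 log units; beyond the scatter). Nothing shown separates one dimethylphenyl from another, so no step beyond the scatter is expected in this assay. Compound 4 is therefore estimated at 30000 nM, between 10000 nM and 90000 nM. That estimate amounts to a 1.3-fold lower number from compound 3 to compound 4 (0.12 log units; within the scatter).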

Compound 4, half-maximal inhibitory concentration: 22000 nM
Beside the measured number, compound 4's estimate is 1.4-fold (0.13 log units) above it; low and high end bracket the measured number.
By their numbers in this assay, from the lowest: compound 1; then compounds 4, 2 and 3 (each within the scatter of the next).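

In this assay, 2,6-dimethylphenyl on the amide-type nitrogen does not separate from the groups it is compared with, as shown by a 1.8-fold lower number from compound 3 to compound 4 (0.26 log units; within the scatter) and by a 1.4-fold lower number from compound 2 to compound 4 (0.15 log units; within the scatter) in turn. Compound 1 alone stands apart, with 4-methoxyphenyl, as the step to 2,6-dimethylphenyl is again beyond the scatter (a 3.2-fold higher number from compound 1 to compound 4 (0.51 log units; beyond the scatter)). Nothing in the available data explains that separation. Still open, from the compounds shown here alone, is whether the separation belongs to the methoxy group itself. A hydroxyl or an amine in its place could stay with compound 1 or join the other three.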